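Working notes: a second fluoro analogue of compound 2

The source may hold more compounds than are shown below. What is called first, only, known or untested is meant among the compounds shown, and "the series" means these compounds.

Measured so far in an assay on mitochondria from L6 cells (Rattus norvegicus) for activation, with a stated time of 90 min; on this read-out higher numbers stand for an effect only at larger amounts of compound and lower numbers for an effect already at smaller amounts:
compound 1 `CCCCOc1cccc(Nc2nc3nonc3nc2O)c1`: 2300 nM
compound 2 `Oc1nc2nonc2nc1Nc1ccccc1`: 66700 nM
compound 3 `Oc1nc2nonc2nc1Nc1cccc(F)c1`: 31200 nM

Compound 2 gives the highest number of the three; compound 3 stands nearest and compound 1 furthest, the latter through a 29-fold higher number from compound 1 to compound 2 (1.46 log units; beyond the scatter). Compound 4 `Oc1nc2nonc2nc1Nc1ccc(F)cc1` is still to be measured. Against compound 2 its change is fluoro in place of hydrogen on an aromatic carbon. Going by the values given here, the one measured step of the same kind is the step from compound 2 to compound 3, which gave a 2.1-fold lower number from compound 2 to compound 3 (0.33 log units; beyond the scatter), a modest step. The step of a 14-fold higher number from compound 1 to compound 3 (1.13 log units; beyond the scatter) concerns butoxy and does not bear on it. A modest lowering in this assay is therefore expected for compound 4, about a 1.9-fold lower number from compound 2 to compound 4 (0.28 log units; within the scatter). Compound 4 is estimated at 35000 nM, range 12000 nM to 100000 nM.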

Compound 4, half-maximal effective concentration: 38600 nM
The estimate for compound 4 lay 1.1-fold (0.04 log units) below the measured number; the measured number falls inside the stated range.
By their numbers in this assay, from the lowest: compound 1; then compounds 3, 4 and 2 (each within the scatter of the next, the first and the last beyond it).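

With fluoro in place of hydrogen para to a large group, a 1.7-fold lower number from compound 2 to compound 4 (0.24 log units; within the scatter) in this assay, so this change at this position is not separated from the unsubstituted ring of compound 2. Compound 3 and compound 4 also lie within the scatter of each other, so the two fluoro positions cannot be told apart on these numbers. Nothing available bears on the reason for this result.

As far as these compounds go, whether a larger group para to the large group could move the number remains open. An amine, a carboxylic acid or a longer alkoxy chain at this place would test that.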